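Notes: quinolin-6-yl replaced by 4-methylphenyl in the series

The compounds below may be only part of what the source reports. "The series", "measured", "known", "first", "only" and "open" are said of these compounds alone.

compound 1 `CCCCC(Sc1ccc(OCCCOc2ccccc2OC)cc1)C(=O)O` — > 10000 nM
compound 2 `CCCCC(Sc1ccc(OCCCOc2ccc3ncccc3c2)cc1)C(=O)O` — > 10000 nM
compound 3 `CCCCC(Sc1ccc(OCCCOc2ccc(C)cc2)cc1)C(=O)O` — not yet measured

In an assay for inhibition of Polyunsaturated fatty acid 5-lipoxygenase (Homo sapiens), read by HPLC, with a stated time of 10 min (on this read-out lower numbers stand for stronger inhibition and higher numbers for weaker inhibition), compound 1 gives > 10000 nM, a limit of the assay, not a number. In this assay compound 2 gives > 10000 nM, likewise only a limit. The step that the two limits leave unreadable from compound 1 to compound 2 is therefore unreadable, and compound 2 stands at the limit of > 10000 nM in this assay, at which 2 of the 2 values shown sit. Compound 3 differs from compound 2 by 4-methylphenyl in place of quinolin-6-yl on an oxygen on a saturated carbon. Among the compounds with values here, no measured step reads on this change; the only evidence is the limit of > 10000 nM in this assay, at which 2 of the 2 values shown sit. Compound 3 is expected to give a limit again in this assay, with no step beyond the scatter. The expected step is a step that the limit leaves unreadable from compound 2 to compound 3. Compound 3 is estimated at 20000 nM, between 5000 nM and 80000 nM.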

Compound 3, half-maximal inhibitory concentration: > 10000 nM
Compound 3: no number, only a limit (the forecaster's own chance of this, stated with the estimate: 85%); the middle value does not contradict the limit.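

No new step can be read among compound 1, compound 2 and compound 3, since each gives only a limit of the assay, not a number: the limit of > 10000 nM in this assay, at which 3 of the 3 values shown sit.

The compounds shown leave open how the 2-methoxyphenyl, quinolin-6-yl and 4-methylphenyl groups compare once a number can be read.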